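The source may hold more compounds than are shown below. What is called first, only, known or untested is meant among the compounds shown, and "the series" means these compounds.

Working notes on the series built around the bis-trifluoromethyl anilide.

For the measured compounds named here, compound 1 `O=C(Nc1cc(C(F)(F)F)cc(C(F)(F)F)c1)c1cccc(Cl)c1` is the only member with a result in an ADME assay on cells (Macrophage, Mus musculus) for cytotoxicity, read by resazurin assay, with a stated time of 3 days (a lower number here means a stronger inhibitor, a higher number a weaker inhibitor), and even that result is not a number: in this assay compound 1 gives > 60000 nM, a limit of the measurement. Compound 2 `O=C(Nc1cc(C(F)(F)F)cc(C(F)(F)F)c1)c1ccccc1` carries the unsubstituted benzoyl variant of the same core, but in this assay compound 2 has "not determined" (no result reported), so no second number stands beside compound 1. Going by the values given here, what is known of the series is therefore summed up by the limit of > 60000 nM in this assay, at which 1 of the 2 values shown sits; no step between two measured compounds can be drawn.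

Compound 3 `COc1ccc(Cl)cc1C(=O)Nc1cc(C(F)(F)F)cc(C(F)(F)F)c1` differs from compound 1 by methoxy in place of hydrogen on an aromatic carbon. With compound 1 giving only a limit in this assay, no direction beyond the scatter is expected for the change from compound 1 to compound 3; the estimated step that the limit leaves unreadable from compound 1 to compound 3 is taken as essentially flat. For compound 3 the expected result in this assay is 100000 nM, with a range of 25000 nM to 400000 nM, and most likely again reported as a limit rather than a number.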

Compound 3, half-maximal inhibitory concentration: > 60000 nM
Compound 3 was reported as a limit; the forecaster's own chance of this, stated with the estimate: 75%; the middle value does not contradict the limit.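

Compound 1 and compound 3 are both reported only as limits in this assay, so no step between them can be read: the limit of > 60000 nM in this assay, at which 2 of the 3 values shown sit.

The compounds shown leave open whether methoxy in place of hydrogen on an aromatic carbon changes this read-out at all, and whether any member of the series gives a number rather than a limit.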